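Swapping the aryl group: expected tolerance of compound 4

A few compounds are considered here, and "the series" means these few. Any claim that something is new, unique, unknown or untested is made for them only; others in the source may bear on it.

Three measured compounds share one core and differ only in the aryl group attached to the carbon that carries a double bond to nitrogen. Compound 1 `N#Cc1ccc(Nc2nccc(/C(=N\O)c3ccc4ccccc4c3)n2)cc1` in an ADME assay on MT4 cells (Homo sapiens) for cytotoxicity, read by MTT assay, with a stated time of 4 days (a higher number here means that more compound is tolerated, a lower number that less compound is tolerated), gives 31600 nM. Compound 2 `N#Cc1ccc(Nc2nccc(/C(=N\O)c3cccc4ccccc34)n2)cc1` in this assay gives 33100 nM. Compound 3 `COc1cccc(/C(=N/O)c2ccnc(Nc3ccc(C#N)cc3)n2)c1` in this assay gives 30500 nM. The number for compound 3 sits close to both others: compound 1 is the nearer and compound 2 the further away, and both gaps lie within the scatter, so the three compounds are tolerated to the same extent as far as this assay can tell.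

Compound 4 `Cc1ccccc1/C(=N/O)c1ccnc(Nc2ccc(C#N)cc2)n1` differs from compound 3 in one place: 2-methylphenyl in place of 3-methoxyphenyl on a carbon with a double bond to nitrogen. For the measured compounds named here, no measured pair differs in a single place, so no measured step shows how such a swap shifts the reading. What the three measured compounds do show is that rather different groups at that place left the reading flat. The step expected a 1.0-fold higher number from compound 3 to compound 4 (0.01 log units; within the scatter) is therefore none beyond the scatter. Compound 4 is expected to give 31000 nM, within a range from 18000 nM to 55000 nM.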

Compound 4, half-maximal cytotoxic concentration: 29900 nM
Compound 4: middle estimate off by 1.0-fold (0.02 log units), on the high side; the range from low to high includes it.
By their numbers in this assay, from the lowest: compounds 4, 3, 1 and 2 (each within the scatter of the next).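

For the compounds shown here, compound 3 and compound 4 form the first pair here that differs in one place, and in this assay they give a direct reading for swapping one aryl group for another (a 1.0-fold lower number from compound 3 to compound 4 (0.01 log units; within the scatter)). This step lies within the scatter, even though the leaving 3-methoxyphenyl carries one hydrogen-bond acceptor and the entering 2-methylphenyl carries none, so in this pair the oxygen makes no difference that the assay can detect. The swap exchanges methoxy for methyl and also alters the numbered place of that group on the ring, so this single step cannot separate the two changes. Nothing in the data at hand offers a reason for this result.

At this place, the compounds shown carry only aromatic rings of carbon with no net charge, so they leave open whether the reading would stay within the scatter with an amine, a carboxylic acid or a longer chain there. One pair also cannot show whether a methyl and a methoxy group would be equally interchangeable at other numbered places on the ring.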